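The compounds below may be only part of what the source reports. "The series", "measured", "known", "first", "only" and "open" are said of these compounds alone.

Compound 1, `CN(C)c1ncnc2c1c(-c1ccoc1)cn2[C@@H]1O[C@H](CO)[C@@H](O)[C@H]1O`: in a functional assay on HCT-116 cells (Homo sapiens), read by MTT assay, with a stated time of 72 h (on this read-out higher numbers stand for weaker inhibition and lower numbers for stronger inhibition), compound 1 gives > 20000 nM, a limit of the assay rather than a number.
Compound 2, `CSc1ncnc2c1c(-c1ccoc1)cn2[C@@H]1O[C@H](CO)[C@@H](O)[C@H]1O`: compound 2 gives 100 nM.
Compound 3, `CSc1ncnc2c1c(-c1cccs1)cn2[C@@H]1O[C@H](CO)[C@@H](O)[C@H]1O`: compound 3 gives > 20000 nM, again a limit and not a number.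

Two single changes start from compound 2. The first, (dimethylamino in place of methylsulfanyl on an aromatic carbon), gives an at least 200-fold higher number from compound 2 to compound 1 (2.30 log units; beyond the scatter). The second, (thiophen-2-yl in place of furan-3-yl on an aromatic carbon), gives an at least 200-fold higher number from compound 2 to compound 3 (2.30 log units; beyond the scatter). As far as these compounds go, both end at the limit of > 20000 nM in this assay, at which 2 of the 3 values shown sit, so the true size of each step is unknown beyond that.

Compound 4, `CN(C)c1ncnc2c1c(-c1cccs1)cn2[C@@H]1O[C@H](CO)[C@@H](O)[C@H]1O`, differs from compound 3 by dimethylamino in place of methylsulfanyl on an aromatic carbon, the same change as from compound 2 to compound 1, at a place described in the same words. The cores of compound 3 and compound 2 differ by thiophen-2-yl in place of furan-3-yl on an aromatic carbon.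

Because compound 3 already sits at > 20000 nM and the same change gave an at least 200-fold higher number from compound 2 to compound 1 (2.30 log units; beyond the scatter), compound 4 is expected to stay beyond that limit, with an estimated step that the limit leaves unreadable from compound 3 to compound 4. Compound 4 is estimated at 40000 nM in this assay, plausibly between 20000 nM and 200000 nM.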

Compound 4, half-maximal inhibitory concentration: > 20000 nM
Compound 4: no number, only a limit (the forecaster's own chance of this, stated with the estimate: 95%); the middle value lies beyond the limit too.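

In this assay compound 4 gives > 20000 nM, again a limit and not a number, so no step linking it to compound 1 or compound 3 can be read: the limit of > 20000 nM in this assay, at which 3 of the 4 values shown sit.

As far as these compounds go, how far beyond that limit compound 1, compound 3 and compound 4 each lie stays open, and so does whether the two changes together do more than either alone.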